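The source may report more compounds than this note shows. Statements on the series, on what has been measured and on what is new or still open speak of the compounds shown alone.

Of the compounds shown here, two have been measured in an assay on CHO cells for displacement of a labelled ligand from Glucagon receptor (Homo sapiens), read by scintillation counting, with a stated time of 60 min; a lower number here means a stronger inhibitor, a higher number a weaker inhibitor. Compound 1 `C[C@H](c1ccc(C(=O)NCCC(=O)O)cc1)N1C(=O)C(c2cccc(C3CC3)c2)=N[C@]12CC[C@@H](C(C)(C)C)CC2` gives 56 nM in this assay. Compound 2 `CCCCC[C@H](c1ccc(C(=O)NCc2nn[nH]n2)cc1)N1C(=O)C(c2cc(Cl)cc(Cl)c2)=N[C@]12CC[C@@H](C(C)(C)C)CC2` gives 24 nM in this assay. Compound 1 stands highest of the two numbers; its nearest neighbour is compound 2, whose number is lower by a gap that lies beyond the usual scatter. For the measured compounds named here, compound 1 and compound 2 differ in several places at once, so the two values show only that compound 2 is the stronger binder of the pair, and no single change can be tied to the gap.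

Compound 3 `C[C@H](c1ccc(C(=O)NCCC(=O)O)cc1)N1C(=O)C(c2cccc(Cl)c2F)=N[C@]12CC[C@@H](C(C)(C)C)CC2` has not yet been measured. It differs from compound 1 in one place: 3-chloro-2-fluorophenyl in place of 3-cyclopropylphenyl on a carbon with a double bond to nitrogen. Going by the values given here, no step between measured compounds covers a change of this kind, and compound 2, which also differs from compound 1 in other places, gives no clean guide. The expectation for compound 3 is therefore a modest step from compound 1, a 1.4-fold lower number from compound 1 to compound 3 (0.15 log units; within the scatter), leaning towards a lower number, with the value of compound 2, 24 nM, taken as a loose pointer. Compound 3 is estimated at 40 nM, within a range from 15 nM to 130 nM.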

Compound 3, half-maximal inhibitory concentration: 620 nM
For compound 3 the middle estimate is 16-fold (1.19 log units) below the measured one; the whole stated range lies below it.
By their numbers in this assay, from the lowest: compound 2; then compound 1; then compound 3.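

In this assay the group on a carbon with a double bond to nitrogen turns out to be a sensitive place: with the rest of compound 1 held fixed, 3-chloro-2-fluorophenyl in place of 3-cyclopropylphenyl gives an 11-fold higher number from compound 1 to compound 3 (1.04 log units; beyond the scatter) in a single change. Compound 1 and compound 2 differ in several places at once and could not show this; here one substituted phenyl replaces another, neither side carries a hydrogen-bond donor or acceptor or a net charge, and binding still weakens by a large step. Nothing measured here accounts for the size of this step.

It remains open whether the step follows from the loss of the cyclopropyl ring or from the arrival of the chlorine and fluorine, as the compounds shown include no 3-chlorophenyl or 2-fluorophenyl at this place on the shared core. Also open, from the compounds shown here alone, is whether a plain phenyl or a 3-isopropylphenyl here would stand nearer to compound 1 or to compound 3.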